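A few compounds are considered here, and "the series" means these few. Any claim that something is new, unique, unknown or untested is made for them only; others in the source may bear on it.

In an ADME assay on L6 cells (Rattus norvegicus) for cytotoxicity, read by resazurin assay, with a stated time of 70 h (on this read-out higher numbers stand for weaker inhibition and lower numbers for stronger inhibition), compound 1 (`COc1cc(NC(C)CCCNC(=O)/C=C/c2ccc(OC)c(OC)c2)c2ncccc2c1`) stands at > 220000 nM, which is a limit and not a number. Compound 2 (`COc1cc(NC(C)CCCNC(=O)/C=C/c2cc(OC)c(OC)c(OC)c2)c2ncccc2c1`) also gives only a limit, > 210000 nM. The methoxy addition is thus a step that the two limits leave unreadable from compound 1 to compound 2, and it offers no guide. Compound 3 (`COc1cc(NC(C)CCCNC(=O)/C=C/c2ccccc2F)c2ncccc2c1`) gives a true number, 3500 nM. Among the compounds with values here, the one readable step is an at least 62-fold lower number from compound 1 to compound 3 (1.79 log units; beyond the scatter), and it also removes the 3,4-dimethoxyphenyl. Compound 4 (`COc1cc(NC(C)CCCNC(=O)/C=C/c2ccc(C(F)(F)F)cc2)c2ncccc2c1`) changes the same place: 4-(trifluoromethyl)phenyl in place of 3,4-dimethoxyphenyl on a double-bonded chain carbon bound to a double-bonded chain carbon. One comparable replacement is thin evidence, but a large move toward a lower number is expected in this assay. The estimated step is an at least 31-fold lower number from compound 1 to compound 4 (1.49 log units; beyond the scatter). Compound 4 is expected at 7000 nM, with an estimated range of 1800 nM to 40000 nM.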

Compound 4, half-maximal inhibitory concentration: 160000 nM
Estimate against measurement, compound 4: 23-fold (1.36 log units) below, outside the stated range (above it).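

Moving away from the 3,4-dimethoxyphenyl is thus not enough on its own to give a low number in this assay, as the choice of replacement matters: 4-(trifluoromethyl)phenyl in place of 2-fluorophenyl gives a 46-fold higher number from compound 3 to compound 4 (1.66 log units; beyond the scatter). Measured against the other neighbour, the change gives an at least 1.3-fold lower number from compound 1 to compound 4 (0.13 log units; that floor lies within the scatter). Compound 1 carries a limit and not a number, so that step is only a floor: the limit of > 220000 nM in this assay, at which 1 of the 4 values shown sits.

The compounds shown leave open whether the low number of compound 3 is tied to its fluorine, and how a phenyl carrying an amine or a carboxylic acid would read on this chain carbon.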